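Swapping Fluoro for Methoxy: An Expected Gain in Response

This account rests on a few compounds, and the source may have more. Where it says the series, first, only, none or still open, it means among the compounds named here.

Compound 1 `c1ccc(C2CCc3nc[nH]c3C2)cc1`: 78%; 75%; 76% (3 entries)
Compound 2 `Fc1ccccc1C1Cc2nccn2C1`: 63%
Compound 3 `COc1ccccc1C1CCc2nc[nH]c2C1`: 95%

All three were tested in a functional assay on CHO cells for agonist activity at Alpha-1A adrenergic receptor (Homo sapiens), read by FLIPR and calcium flux; a lower number here means a smaller maximal response, a higher number a larger maximal response. Compound 2 gives 63%, the lower of the two single numbers recorded. Compound 3 gives 95%, a margin beyond the usual scatter above compound 2, while compound 1, with repeat readings (the several entries of compound 1 in this assay, 78%; 75%; 76% (3 entries)), sits between them. Compound 4 `COc1ccccc1C1Cc2nccn2C1` has not yet been measured. It differs from compound 2 in one place: methoxy in place of fluoro on an aromatic carbon. Among the compounds with values here, no measured pair differs in exactly this way, so the size of the step is uncertain. Compound 3 carries the same methoxy on a different core and gives 95%, so a moderate rise is expected. Compound 4 is estimated at about 80%, within a range from 62% to 98%. The expected step of a number 17 percentage points higher from compound 2 to compound 4 (beyond the scatter) is upward, though it may not exceed the scatter.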

Compound 4, largest response reached (Emax), in percent of the reference or control that the assay uses in the Alpha-1A adrenergic receptor assay: 82%
Compound 4: middle estimate off by 2 percentage points, on the low side, and the stated range covers the measured number.
By their numbers in the Alpha-1A adrenergic receptor assay, from the lowest: compound 2; then compound 4; then compound 3.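

Within the data shown here, this is the first direct reading of methoxy in place of fluoro on this aromatic carbon, and in the Alpha-1A adrenergic receptor assay the step is (a number 19 percentage points higher from compound 2 to compound 4 (beyond the scatter)). In a physicochemical assay for lipophilicity, at pH 7.4 (on this read-out lower numbers stand for lower lipophilicity and higher numbers for higher lipophilicity), compound 2 gives (2) and compound 4 gives (1.9), so the change in response comes with no change beyond the scatter on this read-out. The step in response is also wider than the spread of repeat readings of one compound: the several entries of compound 1 in the Alpha-1A adrenergic receptor assay, 78%; 75%; 76% (3 entries).

On these data alone, whether an amine or a longer chain such as ethoxy on this carbon would give a larger or smaller response stays open. So does how fluoro would read on the core of compound 3.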